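Sulfone analogue with trifluoromethyl: an expected step

The source may report more compounds than this note shows. Statements on the series, on what has been measured and on what is new or still open speak of the compounds shown alone.

Measured compounds:
Compound 1, `CC(O)(CSc1ccc(F)cc1)C(=O)Nc1cccc(S(F)(F)(F)(F)F)c1`: 38500 nM
Compound 2, `CC(O)(CSc1ccc(C(F)(F)F)cc1)C(=O)Nc1cccc(S(F)(F)(F)(F)F)c1`: 27200 nM
Compound 3, `CC(O)(CS(=O)(=O)c1ccc(F)cc1)C(=O)Nc1ccc(S(F)(F)(F)(F)F)cc1`: 27700 nM

All three were tested in a functional assay on DU-145 cells (Homo sapiens) for antiproliferative activity, read by propidium iodide staining, with a stated time of 96 h; a higher number here means a weaker inhibitor, a lower number a stronger inhibitor. Compound 1 and compound 2 share a core, and the change between them is trifluoromethyl in place of fluoro on an aromatic carbon. That change gave a 1.4-fold lower number from compound 1 to compound 2 (0.15 log units; within the scatter).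

Compound 3 has a different core; the difference between the core of compound 3 and the core of compound 1 is not broken down here. Compound 3 and compound 2 give numbers that lie within the scatter of each other, as do compound 3 and compound 1.

The unmeasured compound 4, `CC(O)(CS(=O)(=O)c1ccc(C(F)(F)F)cc1)C(=O)Nc1ccc(S(F)(F)(F)(F)F)cc1`, is made from compound 3 by trifluoromethyl in place of fluoro on an aromatic carbon. This is the same change as that from compound 1 to compound 2, at a place described in the same words. In this assay the expected step is a 1.4-fold lower number from compound 3 to compound 4 (0.14 log units; within the scatter), because the same change gave a 1.4-fold lower number from compound 1 to compound 2 (0.15 log units; within the scatter). Compound 4 is therefore estimated at 20000 nM, with a range from 8000 nM to 45000 nM.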

Compound 4, half-maximal inhibitory concentration: 29300 nM
The estimate for compound 4 lay 1.5-fold (0.17 log units) below the measured number; the measured number falls inside the stated range.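

In this assay, trifluoromethyl in place of fluoro on the core of compound 3 gave a 1.1-fold higher number from compound 3 to compound 4 (0.02 log units; within the scatter) and so adds a second small step to set against the first: the same change on two cores in this assay, a 1.4-fold lower number (0.15 log units; within the scatter) from compound 1 to compound 2 and a 1.1-fold higher number (0.02 log units; within the scatter) from compound 3 to compound 4, 1.5-fold (0.18 log units) apart, within the scatter of two such steps.

The change from 4-fluorophenyl to 4-(trifluoromethyl)phenyl therefore stayed within the scatter on both cores, and the two steps cannot be told apart. This does not show that the change would carry over in the same way if it had a larger effect, since neither step is large enough to test that, nor does it show that the change is without effect on other cores in the series.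

The compounds shown leave open whether an amine, a carboxylic acid or a longer chain in place of fluoro would move the number beyond the scatter. They also leave open whether any single part of the difference between the two cores alters the number, since the core of compound 1 and the core of compound 3 are never compared one change at a time.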